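The source may hold more compounds than are shown below. What is called first, only, known or untested is meant among the compounds shown, and "the series" means these compounds.

Of the compounds shown here, three have so far been measured in an assay on cell membranes (strain Wistar) for displacement of a labelled ligand from 5-hydroxytryptamine receptor 7 (Rattus norvegicus); on this read-out lower numbers stand for stronger inhibition and higher numbers for weaker inhibition. Compound 1 `CCCOc1nc2c(c(=O)n(C)c(=O)n2C)n1CCCN1CCN(c2ccccc2)CC1` gives 980 nM. Compound 2 `CCCOc1nc2c(c(=O)n(C)c(=O)n2C)n1CCCN1CCN(c2cccc(Cl)c2)CC1` gives 267 nM. Compound 3 `Cn1c(=O)c2c([nH]c(=O)n2CCCCN2CCN(c3ccccc3)CC2)n(C)c1=O` gives 1820 nM.

Compound 1 and compound 2 share one core and differ by a single change, (chloro in place of hydrogen on an aromatic carbon). This change brought a 3.7-fold lower number from compound 1 to compound 2 (0.56 log units; beyond the scatter). Compound 3 is built on a different core; the difference between the two cores is not broken down here. The numbers of compound 3 and compound 1 lie within the usual scatter of each other, while the number of compound 2 is lower than that of compound 3 by more than the scatter.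

Compound 4 `Cn1c(=O)c2c([nH]c(=O)n2CCCCN2CCN(c3cccc(Cl)c3)CC2)n(C)c1=O` has not yet been measured. It differs from compound 3 by chloro in place of hydrogen on an aromatic carbon, the same change as that from compound 1 to compound 2, at the same place in the ring. If the change behaves in the second core as it did in the first, compound 4 should land clearly below compound 3. Among the compounds with values here, the step from compound 3 to compound 4 is expected to be a 3.3-fold lower number from compound 3 to compound 4 (0.52 log units; beyond the scatter), resting on the single measured step of a 3.7-fold lower number from compound 1 to compound 2 (0.56 log units; beyond the scatter) seen in one core only. Compound 4 is therefore estimated at 550 nM, with a range from 250 nM to 1200 nM.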

Compound 4, inhibition constant: 3670 nM
The estimate for compound 4 lay 6.7-fold (0.82 log units) below the measured number; the measured number lies above the stated range.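

In this assay, going from phenyl to 3-chlorophenyl on the second core gives a 2.0-fold higher number from compound 3 to compound 4 (0.30 log units; within the scatter), so on this core the chloro produces no change that can be told apart from the scatter. The gain seen on the first core therefore did not carry over, and the two steps differ by more than measurement noise would allow: the same change on two cores in this assay, a 3.7-fold lower number (0.56 log units; beyond the scatter) from compound 1 to compound 2 and a 2.0-fold higher number (0.30 log units; within the scatter) from compound 3 to compound 4, 7.4-fold (0.87 log units) apart, beyond the scatter of two such steps. This shows that, in this series, the effect of the chloro depends on the core that carries it, but it does not show which part of the core matters or how the difference arises.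

Within the data shown here, with only one pair on each core, it remains open how far either step speaks for other compounds built on that core. As far as these compounds go, it is also open whether a fluoro or a methoxy group at the same place on the ring would behave differently on the two cores, as the chloro does.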